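A few compounds are considered here, and "the series" means these few. Any claim that something is new, unique, unknown or untested is made for them only; others in the source may bear on it.

Measured so far:
compound 1 `COc1ccc(OC)c(-c2cc(-c3ccc(Cl)cc3)nn2-c2ccc(S(=O)(=O)NC(C)=O)cc2)c1` gives 52600 nM
compound 2 `CC(=O)NS(=O)(=O)c1ccc(-n2nc(-c3ccccc3)cc2-c2cc(O)ccc2O)cc1` gives 100000 nM

Both numbers come from a functional assay on cells (Cancer cell lines, Homo sapiens) for cytotoxicity, read by sulforhodamine B assay, with a stated time of 48 h; a higher number here means a weaker inhibitor of growth, a lower number a stronger inhibitor of growth. In this assay compound 2 gives 100000 nM and compound 1 gives 52600 nM; the two lie within the scatter of each other, so neither can be placed above the other. Compound 3 `CC(=O)NS(=O)(=O)c1ccc(-n2nc(-c3ccc(Cl)cc3)cc2-c2cc(O)ccc2O)cc1` carries chloro in place of hydrogen on an aromatic carbon relative to compound 2; read one bond further out, the change is phenyl to 4-chlorophenyl. For the measured compounds named here, no measured pair shows this change in isolation, so the size of the step is open. The step is expected to be small, a 1.5-fold lower number from compound 2 to compound 3 (0.19 log units; within the scatter), in either direction. The estimate for compound 3 is 65000 nM, within 25000 nM to 150000 nM.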

Compound 3, concentration for total growth inhibition: 73700 nM
For compound 3 the middle estimate is 1.1-fold (0.05 log units) below the measured one; the range from low to high includes it.
By their numbers in this assay, from the lowest: compounds 1, 3 and 2 (each within the scatter of the next).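

In this assay, chloro in place of hydrogen on an aromatic carbon, para to a large group, gives a 1.4-fold lower number from compound 2 to compound 3 (0.13 log units; within the scatter) and so has no effect that can be separated from the scatter at this position. 2,5-Dihydroxyphenyl in place of 2,5-dimethoxyphenyl on an aromatic carbon gives a 1.4-fold higher number from compound 1 to compound 3 (0.15 log units; within the scatter) and is equally unresolved, so neither change separates these compounds. From the compounds shown here alone, whether an amine or a carboxylic acid in place of the chloro would give a step beyond the scatter remains open. No available data bear on why both steps are this small.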